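The source may hold more compounds than are shown below. What is called first, only, known or untested is meant among the compounds shown, and "the series" means these compounds.

Three compounds have so far been measured in an assay on HEK293 cells for inhibition of Steryl-sulfatase (Homo sapiens), tested at 0.1 uM; on this read-out higher numbers stand for a stronger effect at the one concentration tested and lower numbers for a weaker effect:

- compound 1 `NS(=O)(=O)Oc1ccc2c(c1)CN(C(=O)c1cccc(N3CCN(c4ncccn4)CC3)c1)CC2` gives 1.6%
- compound 2 `CCN(Cc1ccc(Br)cc1)c1cccc(C(=O)N2CCc3ccc(OS(N)(=O)=O)cc3C2)c1` gives 24.2%
- compound 3 `CCN(Cc1cccnc1)c1ccc(C(=O)N2CCc3ccc(OS(N)(=O)=O)cc3C2)cc1` gives 35.7%

Compound 3 stands highest of these three numbers. The nearest to it is compound 2, whose number lies lower by a gap that is beyond the usual scatter of such measurements, and the furthest is compound 1, whose number lies lower still, also beyond the scatter. All three share the same core; they differ in the group attached to the carbonyl.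

The next compound, compound 4 `CCN(Cc1ccncc1)c1ccc(C(=O)N2CCc3ccc(OS(N)(=O)=O)cc3C2)cc1`, has not yet been measured in this assay. It has the same atoms as compound 3, joined differently: pyridin-4-yl in place of pyridin-3-yl on a saturated chain carbon bound to a nitrogen on an aromatic ring. Among the measured compounds shown here, no pair of measured compounds shows this kind of change, so there is no measured step to lean on. Since the same atoms are only rearranged within one ring, the expectation is a step of no size beyond the scatter, in no particular direction. Compound 4 is therefore expected to give about 33%, with a likely range from 15% to 50%. The estimated step of a number 2.7 percentage points lower from compound 3 to compound 4 (within the scatter) expresses this expectation of little or no change.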

Compound 4, a percentage reported as inhibition, at one concentration (the size of the read-out at that concentration, not a potency): 47%
For compound 4 the middle estimate is 14 percentage points below the measured one; the range from low to high includes it.
By their numbers in this assay, from the lowest: compound 1; then compound 2; then compound 3; then compound 4.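

In this assay, placing pyridin-4-yl where pyridin-3-yl stood, on a saturated chain carbon bound to a nitrogen on an aromatic ring, gives a number 11.3 percentage points higher from compound 3 to compound 4 (beyond the scatter) as a modest but readable step. Among the compounds shown here, this is the first pair of measured compounds that differ in one place, and it shows that this position responds even to a rearrangement within one ring: the two groups have the same heavy atoms and the same hydrogen-bond donor and acceptor counts, yet the read-out does not stay the same. No measurement at hand explains why the number rises with this change.

On these data alone, it remains open how pyridin-2-yl, the remaining arrangement of this ring, or a plain phenyl ring would fare at the same place, and so whether the ring nitrogen matters at all or only its location. As far as these compounds go, it is also open whether the step would hold if the ethyl group on the same nitrogen gave way to a longer chain such as propyl, as a single pair cannot establish a general rule.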